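Pyrrolopyrimidine to carbamoylpyridine ether in the amide series

This account rests on a few compounds, and the source may have more. Where it says the series, first, only, none or still open, it means among the compounds named here.

Three compounds share the quinolone carboxamide core and the fluorinated aryl ether. In an assay on isolated protein for inhibition of tyrosine-protein kinase receptor UFO (Homo sapiens), read by FRET and Z'-LYTE, with a stated time of 1.5 h (a lower number here means a stronger inhibitor, a higher number a weaker inhibitor), compound 1 `Cc1ccc2c(c1)c(=O)c(C(=O)Nc1ccc(Oc3ncnc4[nH]cc(-c5ccccc5)c34)c(F)c1)c(C)n2-c1ccccc1` gives 620 nM, compound 2 `CCc1ccc2c(c1)c(=O)c(C(=O)Nc1ccc(Oc3ncnc4[nH]cc(-c5ccccc5)c34)c(F)c1)c(C)n2C` gives 6 nM, and compound 3 `CCc1ccc2c(c1)c(=O)c(C(=O)Nc1ccc(Oc3ncnc4[nH]ccc34)c(F)c1)c(C)n2C` gives 157 nM. Compound 3 therefore stands second highest of the three numbers in this assay, nearer to compound 1 than to compound 2. Going by the values given here, the one single-site step recorded, a 26-fold higher number from compound 2 to compound 3 (1.42 log units; beyond the scatter), concerns the hydrogen in place of phenyl on an aromatic carbon and is large.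

Compound 4 `CCc1ccc2c(c1)c(=O)c(C(=O)Nc1ccc(Oc3ccnc(C(N)=O)c3)c(F)c1)c(C)n2C` differs from compound 3 by a group of 9 heavy atoms (6 carbon, 2 nitrogen, 1 oxygen; one six-membered aromatic ring with 1 hetero atom) in place of a group of 9 heavy atoms (6 carbon, 3 nitrogen; one five-membered aromatic ring with 1 hetero atom, one six-membered aromatic ring with 2 hetero atoms), on an oxygen on an aromatic ring. Among the compounds with values here, no measured step covers this exchange: the step from compound 2 to compound 3 alters a substituent on the same bicyclic group that now leaves entirely, and compound 1 differs from compound 3 in several places at once, so only its value can be set beside that of compound 3. The size and direction of the step in this assay are therefore open, and no change beyond the scatter is assumed either way.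

Compound 4 is expected to give about 120 nM in this assay, within a wide range from 25 nM to 600 nM, which corresponds to an estimated step of a 1.3-fold lower number from compound 3 to compound 4 (0.12 log units; within the scatter).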

Compound 4, half-maximal inhibitory concentration: 4380 nM
Beside the measured number, compound 4's estimate is 37-fold (1.56 log units) below it; the whole stated range lies below it.
By their numbers in this assay, from the lowest: compound 2; then compound 3; then compound 1; then compound 4.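

In this assay, placing 2-carbamoylpyridin-4-yl on the oxygen on the aromatic ring gives a 28-fold higher number from compound 3 to compound 4 (1.45 log units; beyond the scatter), a large loss of inhibition even though the leaving and entering groups match in their counts of heavy atoms, hydrogen-bond donors and hydrogen-bond acceptors. The earlier step, a 26-fold higher number from compound 2 to compound 3 (1.42 log units; beyond the scatter), showed only that this activity responds to a phenyl on the group that leaves; the new step shows that exchanging that whole group also moves the number well beyond the scatter, so matching those counts does not preserve inhibition in this series. No measured evidence available here bears on the origin of this loss.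

The compounds shown leave open which feature of 2-carbamoylpyridin-4-yl goes with the higher number, since no pair separates the carbamoyl group from the ring that carries it. A nitrile or a methylamide in place of the carbamoyl group would test that, and a phenyl on 2-carbamoylpyridin-4-yl would show whether the gain seen with phenyl in this assay carries over to this group.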